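The source may hold more compounds than are shown below. What is called first, only, known or untested is meant among the compounds shown, and "the series" means these compounds.

Of the compounds shown here, three have so far been measured in an ADME assay on BJ cells (Homo sapiens), read by MTT assay, with a stated time of 72 h; on this read-out lower numbers stand for stronger inhibition and higher numbers for weaker inhibition. Compound 1 `Nc1nc(N)c2c(-c3cc4ccccc4o3)cn([C@@H]3O[C@H](CO)[C@@H](O)[C@H]3O)c2n1` returns only a limit of the assay, > 100000 nM. Compound 2 `Nc1nc2c(c(-c3ccccc3)cn2[C@@H]2O[C@H](CO)[C@@H](O)[C@H]2O)c(=O)[nH]1` likewise returns a limit, > 100000 nM. Among the compounds with values here, compound 3 `O=c1[nH]cnc2c1c(-c1cc3ccccc3o1)cn2[C@@H]1O[C@H](CO)[C@@H](O)[C@H]1O` is the one compound with a number: in this assay compound 3 gives 62700 nM. The other two values sit at the limit of > 100000 nM in this assay, at which 2 of the 3 values shown sit, so compound 3 cannot be placed in order against them beyond saying that it alone produced a measurable number.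

Compound 4 `O=c1[nH]cnc2c1c(-c1ccsc1)cn2[C@@H]1O[C@H](CO)[C@@H](O)[C@H]1O` has not yet been measured. It differs from compound 3 in a single place: thiophen-3-yl in place of 1-benzofuran-2-yl on an aromatic carbon. Within the data shown here, no step between measured compounds is available to size this change, so the expectation rests on compound 3 alone and on the fact that the two other compounds gave no number at all. The estimated step is a 1.6-fold higher number from compound 3 to compound 4 (0.20 log units; within the scatter), toward weaker inhibition or none beyond the scatter. Compound 4 is therefore expected to fall at about 100000 nM, within a range from 40000 nM to 300000 nM, and this assay may well report only a limit for it.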

Compound 4, half-maximal inhibitory concentration: > 100000 nM
Compound 4: only a limit was reported (the forecaster's own chance of this, stated with the estimate: 60%); the middle value lies on the limit itself.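

In this assay, within the data shown here, the first single-place change that can be read at this aromatic carbon, thiophen-3-yl in place of 1-benzofuran-2-yl, gives an at least 1.5-fold higher number from compound 3 to compound 4 (0.20 log units; that floor lies within the scatter). On these data alone, that figure is only a floor, so the pair shows no gain in inhibition from this change, while the true size of the step stays unknown. Compound 3 remains the only compound with a number, and the series now rests mostly on one boundary: the limit of > 100000 nM in this assay, at which 3 of the 4 values shown sit.

The compounds shown leave open whether an amine, a carboxylic acid or a naphthalen-2-yl group on this aromatic carbon would return a number at all. They also leave open whether thiophen-3-yl would give the same outcome on the core of compound 1, which itself returned only a limit.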